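The source may report more compounds than this note shows. Statements on the series, on what has been measured and on what is new or still open speak of the compounds shown alone.

Measured so far in a functional assay on the whole organism (strain Swiss) with Mus musculus as the target, in the maximal electroshock model, with a stated time of 0.25 h, at a dose of 100 mg/kg by the intraperitoneal route; on this read-out higher numbers stand for a stronger effect at the one dose given and lower numbers for a weaker effect:

- compound 1 `CC(C(=O)N1CCN(c2ccc(Cl)cc2)CC1)N1C(=O)CCC1=O` gives 50%
- compound 2 `CCC(C(=O)N1CCN(c2cccc(F)c2)CC1)N1C(=O)CCC1=O` gives 0%
- compound 3 `CC(C(=O)N1CCN(c2ccccc2F)CC1)N1C(=O)CCC1=O` gives 75%

Compound 3 holds the highest of the three numbers in this assay. Its nearest neighbour is compound 1, the step being a number 25 percentage points higher from compound 1 to compound 3 (beyond the scatter). Among the measured compounds shown here, compound 2 is the furthest away; its value and that of compound 3 are separated by a wide margin, but the two differ in more than one place, so no single step is drawn between them.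

Compound 4 `CC(C(=O)N1CCN(c2cccc(F)c2)CC1)N1C(=O)CCC1=O` is not yet measured. It differs from compound 3 by 3-fluorophenyl in place of 2-fluorophenyl on an amine nitrogen in a ring.

For the measured compounds named here, only one measured step bears on this change, a number 25 percentage points higher from compound 1 to compound 3 (beyond the scatter), and it exchanges a different group altogether, so it is at best indirect. Compound 2 carries the 3-fluorophenyl group that enters here, but on a different core, and its value in this assay is the lowest of the series. Taken together these suggest a downward step for compound 4, of uncertain size. For compound 4 the expected step is a number 35 percentage points lower from compound 3 to compound 4 (beyond the scatter), and its estimated value in this assay is 40%, with a range from 0% to 75%.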

Compound 4, a percentage reported as activity, at one dose (the size of the read-out at that dose, not a potency): 75%
Estimate against measurement, compound 4: 35 percentage points below; low and high end bracket the measured number.
By their numbers in this assay, from the lowest: compound 2; then compound 1; then compounds 3 and 4 (each within the scatter of the next).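

In this assay, 3-fluorophenyl in place of 2-fluorophenyl on the amine nitrogen in a ring gives no change at the digits printed from compound 3 to compound 4 (within the scatter), so at this dose the read-out does not separate the two fluorophenyl isomers. The 3-fluorophenyl group also keeps the gain over 4-chlorophenyl, with a number 25 percentage points higher from compound 1 to compound 4 (beyond the scatter). With 3-fluorophenyl now held constant, hydrogen in place of methyl on the saturated chain carbon gives a number 75 percentage points higher from compound 2 to compound 4 (beyond the scatter), which ties the low value of compound 2 to the chain rather than to the aryl group.

No data shown give a cause for any of these steps. Still open, going by these compounds, is whether the flat result extends to a methoxy group or an unsubstituted phenyl on that ring nitrogen, and how a longer chain behaves with the 2-fluorophenyl group.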